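A few compounds are considered here, and "the series" means these few. Any claim that something is new, unique, unknown or untested is made for them only; others in the source may bear on it.

Measured compounds:
- compound 1, `Cc1nc2ccccc2c(=O)n1/N=C/c1ccc(Oc2ccc(Br)cc2)cc1` — in a physicochemical assay for lipophilicity, in phosphate buffer, measured as octanol-water partition (on this read-out lower numbers stand for lower lipophilicity and higher numbers for higher lipophilicity), compound 1 gives 4.64
- compound 2, `CCCc1nc2ccccc2c(=O)n1/N=C/c1ccc(Oc2ccc(Cl)cc2)cc1` — in this assay compound 2 gives 5.78

Compound 2 stands highest of the two numbers in this assay; its nearest neighbour is compound 1, which lies lower by a gap beyond the scatter. Among the compounds with values here, no pair differing in only one place has been measured, so no step size is known from the data themselves.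

Compound 3, `Cc1nc2ccccc2c(=O)n1/N=C/c1ccc(Oc2ccc(Cl)cc2)cc1`, is not yet measured. It differs from compound 2 by hydrogen in place of ethyl on a saturated chain carbon bound to an aromatic carbon. Because compound 2 gives 5.78 and compound 1, which carries the same methyl on the shared core, gives 4.64, the step from compound 2 to compound 3 is expected to be downward and beyond the scatter, of the size a number 1.08 log units lower from compound 2 to compound 3 (beyond the scatter). Compound 3 is estimated at 4.7, with a range from 4.2 to 5.2.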

Compound 3, partition coefficient: 4.6
Compound 3: the middle estimate sits 0.10 log units above what was measured; measured number inside the range.
By their numbers in this assay, from the lowest: compounds 3 and 1 (each within the scatter of the next); then compound 2.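

Ethyl to hydrogen on a saturated chain carbon bound to an aromatic carbon, which cut one bond further out reads propyl to methyl, gives in this assay a large step, a number 1.18 log units lower from compound 2 to compound 3 (beyond the scatter), and so isolates the effect of this chain on the read-out, which the earlier pair, differing in two places, could not do. Chloro in place of bromo on an aromatic carbon gives a number 0.04 log units lower from compound 1 to compound 3 (within the scatter), so the two halogens are not told apart here when the methyl group is present. No measurement is at hand that explains either step.

As far as these compounds go, whether a longer chain than propyl extends the step, and how an amine or a carboxylic acid on this chain would read, remains open. The compounds shown also leave open whether chloro and bromo stay indistinguishable when propyl replaces methyl.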